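The compounds below may be only part of what the source reports. "The series", "measured", "known", "first", "only" and "open" are said of these compounds alone.

The study concerns two thiazole amides measured for cytotoxicity and another compound that remains to be measured. Compound 1, `Cc1cnc(NC(=O)CCCOc2cncc(Cl)c2)s1`, and compound 2, `N#Cc1cnc(NC(=O)CCCOc2cccc(Cl)c2)s1`, were both tested in an ADME assay on HepG2 cells (Homo sapiens) for cytotoxicity, read by CellTiter-Glo, with a stated time of 48 h; on this read-out higher numbers stand for lower toxicity in this test and lower numbers for higher toxicity in this test. In this assay compound 1 gives 1700 nM, whereas compound 2 gives 420 nM. Among the two numbers available, compound 2 therefore stands lowest, and its gap to compound 1 lies beyond the usual scatter of this assay, so compound 2 is the more toxic of the pair on this read-out. These two compounds differ in more than one place, so their gap cannot be tied to any single change.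

Compound 3, `N#Cc1cnc(NC(=O)CCCOc2ccccc2)s1`, is the next compound to be measured. It differs from compound 2 in one place only: hydrogen in place of chloro on an aromatic carbon. Among the measured compounds shown here, no measured pair in this set isolates that change, so there is nothing here to show its size or direction in this assay. Without such a comparison, compound 3 is expected to show at most a modest step in the direction of lower toxicity, a 1.9-fold higher number from compound 2 to compound 3 (0.28 log units; within the scatter), with the possibility that it stays within the scatter of compound 2. On this basis compound 3 is estimated at 800 nM, with a likely range from 300 nM to 2500 nM.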

Compound 3, half-maximal cytotoxic concentration: 4000 nM
Compound 3: middle estimate off by 5.0-fold (0.70 log units), on the low side; the whole stated range lies below it.
By their numbers in this assay, from the lowest: compound 2; then compound 1; then compound 3.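

Taking the chloro off this aromatic carbon and leaving hydrogen gives a 9.5-fold higher number from compound 2 to compound 3 (0.98 log units; beyond the scatter) in this assay, the first comparison in the set that isolates a single change. It shows that the 3-chlorophenyl to phenyl change moves the number towards lower toxicity in this test, and that the step lies beyond the scatter, so in this pair the read-out responds clearly to what sits at this place, meta to a large group. Nothing in the available evidence bears on the reason for this step.

From the compounds shown here alone, the result rests on one pair, so it remains open whether the same change would move the number in the same direction on the methyl-bearing side of the set represented by compound 1, which differs from compound 2 in more than one place. Going by these compounds, it also remains open whether the step depends on chlorine itself or would also appear with another group at this carbon, such as fluoro, methoxy or an amine.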